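Swapping isopropyl for a pyridylmethyl group: notes on compound 4

The compounds below may be only part of what the source reports. "The series", "measured", "known", "first", "only" and "open" are said of these compounds alone.

Values in an ADME assay on microsomes from liver (Homo sapiens) for metabolic stability, read by LC-MS, with a stated time of 10 min; on this read-out higher numbers stand for a more stable compound and lower numbers for a less stable compound:
compound 1 `CN(C[C@H]1Cc2c(cccc2N2CCN(C3COC3)CC2)CN1)[C@H]1CCCc2cccnc21`: 83.1%
compound 2 `CN(C[C@H]1Cc2c(cccc2N2CCN(C3CC3)CC2)CN1)[C@H]1CCCc2cccnc21`: 15.5%
compound 3 `CC(C)N1CCN(c2cccc3c2C[C@H](CN(C)[C@H]2CCCc4cccnc42)NC3)CC1`: 56.6%

In this assay compound 3, at 56.6%, holds the second highest of the three numbers. The nearest gap is a number 26.5 percentage points lower from compound 1 to compound 3 (beyond the scatter), and the furthest is a number 41.1 percentage points higher from compound 2 to compound 3 (beyond the scatter). Both lie beyond the scatter.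

Compound 4 `CN(C[C@H]1Cc2c(cccc2N2CCN(Cc3ccccn3)CC2)CN1)[C@H]1CCCc2cccnc21` is not yet measured. It carries (pyridin-2-yl)methyl in place of isopropyl on an amine nitrogen in a ring.

All three measured steps fall at this same place, so all of them bear on the change. The third is a number 67.6 percentage points lower from compound 1 to compound 2 (beyond the scatter), which is large, and even the smallest of the three is modest and beyond the scatter. A step within the scatter is therefore not the expectation. None of the three compounds carries an aromatic ring at this place, so the direction is uncertain. A lower number is favoured, though only weakly, given how low compound 2 sits at 15.5%. The expected step is a number 23.6 percentage points lower from compound 3 to compound 4 (beyond the scatter), which is modest to large. For compound 4 the estimate is 33%, with an expected range of 12% to 60%.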

Compound 4, percent of the compound remaining: 4.2%
The estimate for compound 4 lay 28.8 percentage points above the measured number; the whole stated range lies above it.
By their numbers in this assay, from the lowest: compound 4; then compound 2; then compound 3; then compound 1.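

In this assay, (pyridin-2-yl)methyl gives the lowest number of the four compounds at this amine nitrogen, with a large step from the isopropyl compound (a number 52.4 percentage points lower from compound 3 to compound 4 (beyond the scatter)), a larger one from the oxetan-3-yl compound (a number 78.9 percentage points lower from compound 1 to compound 4 (beyond the scatter)) and a modest one from the cyclopropyl compound (a number 11.3 percentage points lower from compound 2 to compound 4 (beyond the scatter)). The bottom of the range at this position therefore no longer belongs to cyclopropyl, and the first aromatic ring placed here extends the spread already seen among the three smaller groups. Nothing available bears on why these numbers fall as they do.

Going by these compounds, it remains open whether the drop follows the aromatic ring itself, its ring nitrogen or the single carbon linking it to the amine nitrogen, and a benzyl group, a (pyridin-3-yl)methyl group or a 2-(pyridin-2-yl)ethyl chain at the same place would begin to separate these. On these data alone, it is also open whether an acetyl group or a second oxetane-bearing chain would hold a number near that of compound 1 at 83.1%.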